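Swapping Cyano for Chloro: From Compound 2 to Compound 3

This account rests on a few compounds, and the source may have more. Where it says the series, first, only, none or still open, it means among the compounds named here.

Measured so far:
Compound 1, `CN(C)C(=S)N/N=C/c1cc2cccnc2s1`: 48400 nM
Compound 2, `N#Cc1ccc(NC(=S)N/N=C/c2ccc3ccccc3n2)cc1`: 20000 nM

Both numbers come from a functional assay on HeLa cells (Homo sapiens) for antiproliferative activity, read by sulforhodamine B assay, with a stated time of 72 h; a lower number here means a stronger inhibitor, a higher number a weaker inhibitor. Compound 2 holds the lower of the two, and compound 1 sits further back by a gap that lies beyond the usual scatter. Compound 3, `S=C(N/N=C/c1ccc2ccccc2n1)Nc1ccc(Cl)cc1`, is not yet measured. It differs from compound 2 in one place: chloro in place of cyano on an aromatic carbon. Within the data shown here, no measured pair shows what this change does here, so the step of a 1.3-fold lower number from compound 2 to compound 3 (0.10 log units; within the scatter) is expected to be small, without a clear direction beyond the scatter. Compound 3 is therefore estimated at 16000 nM, within 5000 nM to 50000 nM.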

Compound 3, half-maximal inhibitory concentration: > 100000 nM
Compound 3: only a limit was reported; the forecaster's own chance of this, stated with the estimate: 10%; middle value at least 6.2-fold (0.79 log units) from the limit.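

Among these compounds, this is the first measured pair that differs in one place, and it shows that the group on this aromatic ring matters: in this assay, going from 4-cyanophenyl to 4-chlorophenyl gives an at least 5.0-fold higher number from compound 2 to compound 3 (0.69 log units; beyond the scatter). Compound 3 reads > 100000 nM, which is a limit of the assay and not a number. The step therefore sets only a floor on the change, and its full size stays unknown: the limit of > 100000 nM in this assay, at which 1 of the 3 values shown sits.

The compounds shown leave open whether an amine, a carboxylic acid or a methoxy group here would track cyano or chloro. They also leave open whether the same swap would act alike on another core.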